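Triaryl series: replacing furan-2-yl with 3-hydroxyphenyl

The source may report more compounds than this note shows. Statements on the series, on what has been measured and on what is new or still open speak of the compounds shown alone.

Measured in a functional assay on MDA-MB-231 cells (Homo sapiens) for cytotoxicity, read by ELISA, with a stated time of 2 days; a lower number here means a stronger inhibitor, a higher number a weaker inhibitor:
- compound 1 `Oc1cccc(-c2cc(-c3ccccc3)cc(-c3ccccc3)n2)c1`: 19300 nM
- compound 2 `Oc1cccc(-c2cc(-c3ccccc3)cc(-c3ccco3)n2)c1`: 13700 nM

Within the data shown here, only two values are available so far, and they lie within the scatter of each other, so compound 2 cannot be ranked apart from compound 1.

The next compound is compound 3 `Oc1cccc(-c2cc(-c3ccccc3)cc(-c3cccc(O)c3)n2)c1`, where 3-hydroxyphenyl takes the place of furan-2-yl: 3-hydroxyphenyl in place of furan-2-yl on an aromatic carbon. Among the measured compounds shown here, the change sits next to the ring nitrogen, so it falls at the same place as the one measured exchange.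

That exchange, phenyl to furan-2-yl, gave a 1.4-fold lower number from compound 1 to compound 2 (0.15 log units; within the scatter). For the measured compounds named here, it is the only guide here, and it shows little response at this place for those two groups. Going by the values given here, no measured compound carries 3-hydroxyphenyl at this place, so the data cannot fix a direction. A small step, not clearly beyond the scatter, is expected in this assay.

The expected step is a 1.2-fold lower number from compound 2 to compound 3 (0.10 log units; within the scatter). For compound 3 the estimated value is 11000 nM, with an expected range of 4000 nM to 28000 nM.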

Compound 3, half-maximal inhibitory concentration: 12800 nM
Compound 3: the middle estimate sits 1.2-fold (0.07 log units) below what was measured; measured number inside the range.
By their numbers in this assay, from the lowest: compounds 3, 2 and 1 (each within the scatter of the next).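

In this assay, 3-hydroxyphenyl in place of furan-2-yl gives a 1.1-fold lower number from compound 2 to compound 3 (0.03 log units; within the scatter), so a six-membered aromatic ring of carbon only, bearing a hydrogen-bond donor, cannot be told apart here from a five-membered aromatic ring with one hetero atom. Hydroxy in place of hydrogen on the phenyl group gives a 1.5-fold lower number from compound 1 to compound 3 (0.18 log units; within the scatter), which adds the first single-group reading of a hydroxy at this place and also stays within the scatter. Across these three compounds, the group next to the ring nitrogen therefore shows no readable effect on the number, and no measurement on hand speaks to why.

As far as these compounds go, it remains open whether any group at this place can move the number beyond the scatter, for instance an amine, a carboxylic acid or a longer alkyl chain. From the compounds shown here alone, the 3-hydroxyphenyl and phenyl groups on the shared core are the same in all three compounds, so what each contributes, including the hydroxy of the constant 3-hydroxyphenyl group, also remains open.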